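An Aryl Swap on a Scaffold That Shows No Inhibition

This account rests on a few compounds, and the source may have more. Where it says the series, first, only, none or still open, it means among the compounds named here.

Compound 1 `CC(C)n1ncc2c(C(=O)NC3CCCC3)cccc21` and compound 2 `CC(C)n1ncc2c(C(=O)NCc3cn(-c4cccc(Br)c4)nn3)cccc21` share the same core, which carries an amide. In a functional assay on MCF7 cells (Homo sapiens) for inhibition, read by MTT assay, with a stated time of 72 h (a higher number here means a weaker inhibitor, a lower number a stronger inhibitor), compound 1 reaches only the assay limit of > 40000 nM, which is not a true number. Compound 2 likewise sits at the limit of > 40000 nM in this assay. All the evidence so far is the limit of > 40000 nM in this assay, at which 2 of the 2 values shown sit. Compound 3 `CC(C)n1ncc2c(C(=O)NCc3cn(-c4ccc(C(F)(F)F)cc4)nn3)cccc21` differs from compound 2 by 4-(trifluoromethyl)phenyl in place of 3-bromophenyl on an aromatic nitrogen. Within the data shown here, with no measured step to draw on, no change beyond the scatter is expected, and the estimated step is a number no higher from compound 2 to compound 3 (the limit leaves the size open). Compound 3 is expected to give about 40000 nM in this assay, between 20000 nM and 80000 nM.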

Compound 3, half-maximal inhibitory concentration: > 40000 nM
Compound 3: no number, only a limit; the forecaster's own chance of this, stated with the estimate: 85%; the middle value lies on the limit itself.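

Among these compounds, compound 2 and compound 3 both sit at a limit of this assay, not at true numbers, so no step between them can be read. The compounds shown leave open what inhibition, if any, this shared core can reach.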